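Swapping a Side Chain End on a Liver-Cell Toxicity Core

The compounds below may be only part of what the source reports. "The series", "measured", "known", "first", "only" and "open" are said of these compounds alone.

Within the data shown here, compound 1 `O=C1c2c[n+]([O-])c3ccccc3c2C(=O)c2c1c1ccccc1n2CCCCN1CCNCC1` is one of two compounds measured in a toxicity assay on L02 cells (Homo sapiens) for cytotoxicity, read by MTT assay, with a stated time of 72 h; a higher number here means a weaker inhibitor, a lower number a stronger inhibitor. In this assay compound 1 gives 1380 nM, the lowest of the two numbers. Its nearest neighbour is compound 2 `CC1(C)OC[C@@H](Cn2cc(Cn3c4c(c5ccccc53)C(=O)c3c[n+]([O-])c5ccccc5c3C4=O)nn2)O1`, which in this assay gives 2900 nM; the gap between these two numbers lies beyond the scatter of repeated measurements.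

Compound 3 `O=C1c2c[n+]([O-])c3ccccc3c2C(=O)c2c1c1ccccc1n2CCCN1CCC(O)CC1` has not yet been measured. Compared with compound 1 it carries one change: 4-hydroxypiperidin-1-yl in place of (piperazin-1-yl)methyl on a saturated chain carbon, three bonds along the chain from an aromatic nitrogen. The shared core is untouched, so whatever difference appears must come from this swap at the end of the side chain.

Among the measured compounds shown here, with no comparable pair already measured, there is no direct guide to the size of this step. Compound 3 is therefore expected to land close to compound 1, with a step of a 1.1-fold higher number from compound 1 to compound 3 (0.04 log units; within the scatter) that is not expected to reach beyond the scatter. The estimate for compound 3 in this assay is 1500 nM, in a range from 600 nM to 4000 nM.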

Compound 3, half-maximal inhibitory concentration: 120 nM
For compound 3 the middle estimate is 13-fold (1.10 log units) above the measured one, and the stated range ends above it.
By their numbers in this assay, from the lowest: compound 3; then compound 1; then compound 2.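

Changing the end of the side chain gives a 12-fold lower number from compound 1 to compound 3 (1.06 log units; beyond the scatter) in this assay, so this part of the molecule can shift the number strongly even with the shared core untouched, something compound 1 and compound 2 alone could not show. The size of the step stands out. The groups that leave and enter match in much of what is counted: each has 7 heavy atoms, a six-membered non-aromatic ring, 1 hydrogen-bond donor and 2 hydrogen-bond acceptors, with no net charge. Nothing available here explains the size of this step.

The change can also be read as 4-(piperazin-1-yl)butyl to 3-(4-hydroxypiperidin-1-yl)propyl, so the ring at the end of the chain and the length of the chain differ together, and the compounds shown cannot separate the two. A 3-(piperazin-1-yl)propyl chain or a 4-(4-hydroxypiperidin-1-yl)butyl chain on the same core would divide the step between them, while a morpholin-4-yl end would test how much depends on the hydroxyl group.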